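This account rests on a few compounds, and the source may have more. Where it says the series, first, only, none or still open, it means among the compounds named here.

Measured so far in a functional assay on the whole organism for inhibition, with Rattus norvegicus as the target, read by paw edema, at a dose of 100 mg/kg by the oral route; on this read-out lower numbers stand for less inhibition and higher numbers for more inhibition at the one dose given (going by the name of the read-out):
compound 1 `O=C(Nc1ccc(Cl)cc1)c1c(O)c2cccnc2n(-c2ccccc2)c1=O` gives 11.6%
compound 2 `O=C(Nc1ccc([N+](=O)[O-])cc1)c1c(O)c2cccnc2n(-c2ccccc2)c1=O` gives -7.6%
compound 3 `O=C(Nc1cccc(Cl)c1)c1c(O)c2cccnc2n(-c2ccccc2)c1=O` gives 7.6%

Compound 1 and compound 3 share one core and are built from the same atoms joined differently; the difference is 3-chlorophenyl in place of 4-chlorophenyl on an amide-type nitrogen, and the step of a number 4 percentage points lower from compound 1 to compound 3 (within the scatter) shows the two values lie close together. Going from compound 1 to compound 2 means (nitro in place of chloro on an aromatic carbon), and this change gave a number 19.2 percentage points lower from compound 1 to compound 2 (beyond the scatter).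

Compound 4 `O=C(Nc1cccc([N+](=O)[O-])c1)c1c(O)c2cccnc2n(-c2ccccc2)c1=O` is not yet measured. It arises from compound 3 by nitro in place of chloro on an aromatic carbon. Among the measured compounds shown here, this is the same kind of change as the one from compound 1 to compound 2, but not the same: there the nitro sits para to a large group, here meta to a large group. Resting on the single earlier step of a number 19.2 percentage points lower from compound 1 to compound 2 (beyond the scatter), a step of a number 14.6 percentage points lower from compound 3 to compound 4 (beyond the scatter) is expected here, with some allowance for the different place. Compound 4 is therefore estimated at -7%, expected to fall between -25% and 10%.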

Compound 4, a percentage reported as inhibition, in the whole organism at one dose (the size of the read-out at that dose, not a potency): 5.7%
Compound 4: the middle estimate sits 12.7 percentage points below what was measured; the range from low to high includes it.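

The change from chloro to nitro does not give one fixed step across this series in this assay: the same change on two cores in this assay, a number 19.2 percentage points lower (beyond the scatter) from compound 1 to compound 2 and a number 1.9 percentage points lower (within the scatter) from compound 3 to compound 4, 17.3 percentage points apart, beyond the scatter of two such steps

With the chloro or nitro group in the 3-substituted phenyl, the swap gives a number 1.9 percentage points lower from compound 3 to compound 4 (within the scatter), while 3-nitrophenyl in place of 4-nitrophenyl gives a number 13.3 percentage points higher from compound 2 to compound 4 (beyond the scatter) and 3-nitrophenyl in place of 4-chlorophenyl gives a number 5.9 percentage points lower from compound 1 to compound 4 (within the scatter). A step seen in one pair therefore cannot simply be carried over to the other, yet two pairs do not show why they differ or how the change would behave on any further core.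

The compounds shown leave open what an amine or a carboxylic acid would give on the same phenyl ring. They also leave open how these compounds would compare at any other dose.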